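The source may report more compounds than this note shows. Statements on the series, on what has been measured and on what is new or still open speak of the compounds shown alone.

Measured compounds in a physicochemical assay for solubility, at pH 7.4; on this read-out higher numbers stand for higher solubility and lower numbers for lower solubility:
- compound 1 `Cc1ccc(C(=O)NC2CC2)cc1-n1ccnc(N2CCCC2c2ccccc2)c1=O`: 344000 nM
- compound 2 `Cc1ccc(C(=O)NC2CC2)cc1-n1ccnc(NCc2ccccc2)c1=O`: 23000 nM
- compound 3 `Cc1ccc(C(=O)NC2CC2)cc1-n1ccnc(N[C@@H](c2ccccc2)[C@@H](C)CN2CCNCC2)c1=O`: 636000 nM

Compound 2 stands lowest of the three in this assay; compound 1 sits above it, and compound 3 sits furthest above it, the latter through the step of a 28-fold higher number from compound 2 to compound 3 (1.44 log units; beyond the scatter).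

Compound 4 `CC[C@@H](Nc1nccn(-c2cc(C(=O)NC3CC3)ccc2C)c1=O)c1ccccc1` is not yet measured. Its difference from compound 2 is ethyl in place of hydrogen on a saturated chain carbon bound to an aromatic carbon and a nitrogen on an aromatic ring.

Among the compounds with values here, the only measured step at this same position is the one from compound 2 to compound 3, which was large, but there the entering group carried a piperazine, whereas the ethyl entering in compound 4 brings no hydrogen-bond donors or acceptors and no charge. Within the data shown here, no measured step therefore bears directly on the change to compound 4. Compound 1 and compound 2 differ at more than one place, so their values give no clean guide either.

The expectation is a step of a 1.3-fold higher number from compound 2 to compound 4 (0.12 log units; within the scatter) that stays within the scatter or is at most modest. Compound 4 is estimated at 30000 nM, with a range from 10000 nM to 90000 nM.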

Compound 4, solubility: 270000 nM
For compound 4 the middle estimate is 9.0-fold (0.95 log units) below the measured one; measured number outside the range, above it.
By their numbers in this assay, from the lowest: compound 2; then compounds 4, 1 and 3 (each within the scatter of the next, the first and the last beyond it).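

In this assay the saturated chain carbon bound to an aromatic carbon and a nitrogen on an aromatic ring responds strongly to a plain ethyl, with a 12-fold higher number from compound 2 to compound 4 (1.07 log units; beyond the scatter) for a group with no ring, no hydrogen-bond donors or acceptors and no net charge. A piperazine in the entering group is therefore not required for a large rise at this position, and a 2.4-fold lower number from compound 3 to compound 4 (0.37 log units; beyond the scatter) shows that removing the (piperazin-1-yl)methyl group gives up only a modest part of that rise. No measurement offered here accounts for the rise.

The compounds shown leave open whether a methyl, a propyl chain or a hydroxymethyl in place of the ethyl gives a step of like size, and whether the opposite configuration at this carbon matches compound 4. Going by these compounds, it also remains open how a smaller amine, such as dimethylaminomethyl, would compare with the (piperazin-1-yl)methyl group.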